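The source may report more compounds than this note shows. Statements on the series, on what has been measured and on what is new or still open speak of the compounds shown alone.

Measured so far in an assay on microsomes from liver for inhibition of 3-hydroxy-3-methylglutaryl-coenzyme A reductase (Rattus norvegicus), read by scintillation counting, with stated times of 0.5 h and 0.75 h; a lower number here means a stronger inhibitor, a higher number a weaker inhibitor:
compound 1 `Cc1c(C(=O)NCc2ccccc2)nc(-c2ccc(F)cc2)n1CC[C@@H](O)C[C@@H](O)CC(=O)O` gives 94 nM
compound 2 `CCc1c(C(=O)NCc2ccccc2)nc(-c2ccc(F)cc2)n1CC[C@@H](O)C[C@@H](O)CC(=O)O` gives 123 nM

Among the compounds with values here, compound 2 holds the higher of the two numbers in this assay, though its only neighbour, compound 1, lies within the scatter of it: the single step seen, a 1.3-fold higher number from compound 1 to compound 2 (0.12 log units; within the scatter), was small. Compound 3 `CC(C)c1c(C(=O)NCc2ccccc2)nc(-c2ccc(F)cc2)n1CC[C@@H](O)C[C@@H](O)CC(=O)O` differs from compound 2 by methyl in place of hydrogen on a saturated chain carbon bound to an aromatic carbon and a saturated chain carbon. The step from compound 1 to compound 2 is the only one that bears on this change, and it stayed within the scatter, so no step beyond the scatter is expected in this assay for compound 3. Compound 3 is estimated at 150 nM, between 70 nM and 330 nM, a step of a 1.2-fold higher number from compound 2 to compound 3 (0.09 log units; within the scatter).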

Compound 3, half-maximal inhibitory concentration: 7.9 nM
For compound 3 the middle estimate is 19-fold (1.28 log units) above the measured one, outside the stated range (below it).
By their numbers in this assay, from the lowest: compound 3; then compounds 1 and 2 (each within the scatter of the next).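

In this assay, methyl in place of hydrogen on the saturated chain carbon bound to an aromatic carbon and a saturated chain carbon gives a large step, a 16-fold lower number from compound 2 to compound 3 (1.19 log units; beyond the scatter), and isopropyl in place of methyl gives a 12-fold lower number from compound 1 to compound 3 (1.08 log units; beyond the scatter). The same kind of addition made one carbon earlier stayed within the scatter, so at this position its effect depends on the carbon that receives the methyl. Nothing shown here accounts for the size of this step. From the compounds shown here alone, whether tert-butyl, cyclopropyl or a longer chain in place of isopropyl keeps the number this low remains open.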